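Swapping Chloro for Methyl on a Benzyl Ring

The source may report more compounds than this note shows. Statements on the series, on what has been measured and on what is new or still open speak of the compounds shown alone.

Among the compounds with values here, compound 1 `Nc1ccc(/C=C2\SC(=O)N(Cc3ccc(Cl)cc3)C2=O)cc1` is one of two compounds measured in a functional assay on CCRF-CEM cells (Homo sapiens) for cytotoxicity, read by cell counting, with a stated time of 3 days; a higher number here means a weaker inhibitor, a lower number a stronger inhibitor. In this assay compound 1 gives 87000 nM, the higher of the two numbers, while compound 2 `C=C(Br)C(=O)Nc1ccc(/C=C2\SC(=O)N(Cc3cccc(Cl)c3)C2=O)cc1` gives 3700 nM. Within the data shown here, compound 2 differs from compound 1 in more than one place, so no single step connects the pair.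

Compound 3 `Cc1ccc(CN2C(=O)S/C(=C\c3ccc(N)cc3)C2=O)cc1` has not been measured. It differs from compound 1 in one place: methyl in place of chloro on an aromatic carbon. Among the measured compounds shown here, no step between measured compounds tells what such a change does in this assay, so the expectation rests on compound 1 alone. The step from compound 1 to compound 3 is expected to be small, a 1.0-fold higher number from compound 1 to compound 3 (0.01 log units; within the scatter), with no clear direction beyond the scatter of this assay. Compound 3 is therefore expected to give about 90000 nM, within a range from 35000 nM to 250000 nM.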

Compound 3, half-maximal inhibitory concentration: > 250000 nM
Compound 3 gave a limit, no number (the forecaster's own chance of this, stated with the estimate: 20%); middle value at least 2.7-fold (0.44 log units) away from the limit.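

Compound 3 reads > 250000 nM in this assay, and this is a limit of the assay, not a number. Even so, the change from 4-chlorophenyl to 4-methylphenyl can be read as a step: an at least 2.8-fold higher number from compound 1 to compound 3 (0.45 log units; beyond the scatter). This is the first sign that the group on this aromatic carbon, para to a large group, matters in this assay, as methyl in place of chloro weakens a compound that was already weak, so the two groups are not interchangeable here, and the true size of the step remains bounded only from one side: the limit of > 250000 nM in this assay, at which 1 of the 3 values shown sits.

Going by these compounds, what a fluoro, a bromo, a methoxy or an amine at this place would give remains open. So does whether methyl in place of chloro would have a similar effect on compound 2, which already gives a much lower number.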